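Trading an Ester Arm for a Hydrocarbon Chain

The source may report more compounds than this note shows. Statements on the series, on what has been measured and on what is new or still open speak of the compounds shown alone.

Of the compounds shown here, three sharing one core have been measured for lipophilicity. Compound 1 `COC(=O)Cn1c(=O)oc2c(C(=O)/C=C/c3ccc(O)c(F)c3)cccc21` gives 1.31 in a physicochemical assay for lipophilicity, read by HPLC, using the shake flask method, measured as octanol-water partition, with a stated time of 24 h, at pH 7.4; a higher number here means a more lipophilic compound, a lower number a more polar compound. Compound 2 `COC(=O)Cn1c(=O)oc2c(C(=O)/C=C/c3cc(F)c(O)c(F)c3)cccc21` gives 1.07 in this assay, and compound 3 `COC(=O)Cn1c(=O)oc2c(C(=O)/C=C/c3ccc(O)c(O)c3)cccc21` gives 0.86. Among the three, compound 2 sits in the middle: it is a number 0.24 log units lower from compound 1 to compound 2 (within the scatter), and the gap from compound 2 to compound 3 is a number 0.21 log units lower from compound 2 to compound 3 (within the scatter), so its number cannot be ordered against either neighbour with confidence. The larger move, from compound 1 to compound 3, was a number 0.45 log units lower from compound 1 to compound 3 (beyond the scatter).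

Compound 4 `CC(C)=CCn1c(=O)oc2c(C(=O)/C=C/c3cc(F)c(O)c(F)c3)cccc21` is built from compound 2 by a change elsewhere in the molecule: 2-methylprop-1-en-1-yl in place of methoxycarbonyl on a saturated chain carbon bound to an aromatic nitrogen. Going by the values given here, all three measured steps concern the phenyl ring and its fluoro and hydroxy groups; none of them touches the chain on the aromatic nitrogen, so no measured step speaks to this change directly. What can be read from the counted difference is that two hydrogen-bond acceptors leave and none enter, while the count of heavy atoms stays the same. On that basis, the estimate for compound 4 is 2.3, within 1.7 to 2.9, which would be an expected step of a number 1.23 log units higher from compound 2 to compound 4 (beyond the scatter).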

Compound 4, distribution coefficient: 1.13
Estimate against measurement, compound 4: 1.17 log units above; the measured number lies below the stated range.
By their numbers in this assay, from the lowest: compounds 3, 2, 4 and 1 (each within the scatter of the next, the first and the last beyond it).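

Going by these compounds alone, this step is the only reading in the set at the chain on the aromatic nitrogen, since the earlier steps all concern the phenyl ring and its fluoro and hydroxy groups. Replacing methoxycarbonyl with 2-methylprop-1-en-1-yl on a saturated chain carbon bound to an aromatic nitrogen gives a number 0.06 log units higher from compound 2 to compound 4 (within the scatter) in this assay, so this pair cannot be told apart, even though the group that enters consists only of carbon and has no hydrogen-bond acceptors, while the group that leaves has oxygen atoms and does carry them; for this pair, then, the change in the acceptor count did not come with a readable difference in the number. Nothing available accounts for this result.

The compounds shown leave open whether the same swap would read the same way with the phenyl ring of compound 1 or of compound 3, as only the ring shared by compound 2 and compound 4 has been seen with both chains. On these data alone, how a longer hydrocarbon chain, an amine or a carboxylic acid at this position would read in this assay also remains open.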